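A few compounds are considered here, and "the series" means these few. Any claim that something is new, unique, unknown or untested is made for them only; others in the source may bear on it.

Compound 1 `CC1(C)NC(=O)c2sc(-c3ccncc3)cc2N1`: 90 nM in an assay for inhibition of Rho-associated protein kinase 1 (Homo sapiens), read by TR-FRET, with stated times of 5 min and 2 h; a higher number here means a weaker inhibitor, a lower number a stronger inhibitor
Compound 2 `CN1C(=O)c2sc(-c3ccncc3)cc2NC1(C)C`: 240 nM

Within the data shown here, compound 1 has the lower of the two numbers in this assay; its only neighbour is compound 2, reached by a 2.7-fold higher number from compound 1 to compound 2 (0.43 log units; beyond the scatter), a change on the amide-type nitrogen. Compound 3 `CC(C)C1(C)NC(=O)c2sc(-c3ccncc3)cc2N1` differs from compound 1 at another position: isopropyl in place of methyl on a saturated ring carbon. Among the measured compounds shown here, no measured step touches that saturated ring carbon, so the one step known says little about this change. A step that stays within the scatter is therefore expected, a 1.3-fold higher number from compound 1 to compound 3 (0.12 log units; within the scatter), with wide uncertainty. Compound 3 is estimated at 120 nM, between 40 nM and 400 nM.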

Compound 3, half-maximal inhibitory concentration: 35 nM
For compound 3 the middle estimate is 3.4-fold (0.54 log units) above the measured one; the whole stated range lies above it.
By their numbers in this assay, from the lowest: compound 3; then compound 1; then compound 2.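

At this saturated ring carbon, between two ring nitrogen atoms, a larger group than methyl is not just accepted: in this assay, isopropyl in place of methyl gives a 2.6-fold lower number from compound 1 to compound 3 (0.41 log units; beyond the scatter), a change beyond the scatter. So this position can give a stronger inhibitor, whereas the only earlier step, on the amide-type nitrogen, moved the number upward. Nothing shown here gives a reason for this gain.

From the compounds shown here alone, whether a longer chain, such as butyl, would lower the number further remains open. So does the effect of an amine at this carbon.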